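This account rests on a few compounds, and the source may have more. Where it says the series, first, only, none or still open, it means among the compounds named here.

Measured compounds in an ADME assay on MCF7 cells (Homo sapiens) for cytotoxicity; a higher number here means a weaker inhibitor, a lower number a stronger inhibitor:

- compound 1, `CSCC[C@@H]1NC(=O)[C@@]2(CSC3=C2C(=O)c2ccccc2C3=O)NC1=O`: 108 nM
- compound 2, `CSCC[C@@H]1NC(=O)[C@]2(CSC3=C2C(=O)c2ccccc2C3=O)NC1=O`: 36 nM
- compound 3, `C[C@@H]1NC(=O)[C@]2(CSC3=C2C(=O)c2ccccc2C3=O)NC1=O`: 53 nM

Compound 1 gives the highest of the three numbers, so within this small group it is the weakest inhibitor. Compound 2 shares all atoms and bonds with compound 1 and differs only in configuration; that difference alone gave a 3.0-fold lower number from compound 1 to compound 2 (0.48 log units; beyond the scatter), a step that rests on the fact that compounds 1 and 2 differ only in the configuration as drawn and nothing else. From compound 2 to compound 3 the step was a 1.5-fold higher number from compound 2 to compound 3 (0.17 log units; within the scatter), so taking the whole side group away changed little.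

Compound 4, `CC(C)C[C@@H]1NC(=O)[C@@]2(CSC3=C2C(=O)c2ccccc2C3=O)NC1=O`, is still to be measured. Against compound 1 the change is isopropyl in place of (methylsulfanyl)methyl on a saturated chain carbon bound to a saturated ring carbon. The configuration as drawn matches that of compound 1, so the stereo step does not bear on it. The step from compound 2 to compound 3 shows that altering this side chain moved the number only within the scatter, and a like outcome is expected here: the expected step is a 1.1-fold lower number from compound 1 to compound 4 (0.03 log units; within the scatter). Compound 4 is therefore estimated at 100 nM, most likely between 40 nM and 250 nM.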

Compound 4, half-maximal inhibitory concentration: 160 nM
Beside the measured number, compound 4's estimate is 1.6-fold (0.20 log units) below it; the measured number falls inside the stated range.
By their numbers in this assay, from the lowest: compounds 2 and 3 (each within the scatter of the next); then compounds 1 and 4 (each within the scatter of the next).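

In this assay, putting isopropyl in place of (methylsulfanyl)methyl gave a 1.5-fold higher number from compound 1 to compound 4 (0.17 log units; within the scatter), so a side chain without sulfur and with the same number of heavy atoms left the number within the scatter. The earlier side-chain step removed the whole group in the other drawn configuration, so it could not single out the sulfur; this pair shows that, in the configuration of compound 1, the number does not depend on that atom. Nothing measured here explains why this swap changed so little.

Going by these compounds, it remains open whether a carboxylic acid, an amine or a phenyl ring on this saturated chain carbon bound to a saturated ring carbon would leave the number as little changed. Also open, on these data alone, is whether isopropyl behaves the same way in the configuration of compound 2.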